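From Chloromethyl to Phenylethenyl on a Capped Ring Nitrogen

A few compounds are considered here, and "the series" means these few. Any claim that something is new, unique, unknown or untested is made for them only; others in the source may bear on it.

In a functional assay on A549 cells (Homo sapiens) for cytotoxicity, read by MTT assay, with a stated time of 48 h (on this read-out higher numbers stand for weaker inhibition and lower numbers for stronger inhibition), compound 1 `CCN(CC)c1ccc2cc(C(=O)c3ccc(N4CCN(C(=O)CN5CCNCC5)CC4)cc3)oc2c1` gives 320 nM. Compound 2 `CCN(CC)c1ccc2cc(C(=O)c3ccc(N4CCN(C(=O)CN5CCN(C(=O)CCl)CC5)CC4)cc3)oc2c1`, which carries a (chloromethyl)carbonyl in place of hydrogen on the amine nitrogen in a ring, gives 3060 nM. That single known step, a 9.6-fold higher number from compound 1 to compound 2 (0.98 log units; beyond the scatter), leaves compound 2 with the higher of the two measured numbers. Compound 3 `CCN(CC)c1ccc2cc(C(=O)c3ccc(N4CCN(C(=O)CN5CCN(C(=O)/C=C/c6ccccc6)CC5)CC4)cc3)oc2c1` keeps the capped nitrogen but changes what sits on that carbonyl carbon: 2-phenylethenyl in place of chloromethyl on a carbonyl carbon. Going by the values given here, no measured step exchanges one group for another on this carbonyl, so the only guide is that capping the nitrogen weakened inhibition from compound 1 to compound 2, and compound 3 remains capped. Compound 3 is therefore expected to stay near the weaker end, and the estimated step of a 1.0-fold lower number from compound 2 to compound 3 (0.01 log units; within the scatter) is expected to lie within the scatter. Compound 3 is estimated at 3000 nM, with a range from 800 nM to 12000 nM.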

Compound 3, half-maximal inhibitory concentration: 9450 nM
Compound 3: the middle estimate sits 3.2-fold (0.50 log units) below what was measured; low and high end bracket the measured number.
By their numbers in this assay, from the lowest: compound 1; then compound 2; then compound 3.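

In this assay, the step of a 3.1-fold higher number from compound 2 to compound 3 (0.49 log units; beyond the scatter) shows that the group on the carbonyl carbon matters, not just the presence of a cap on the ring nitrogen: 2-phenylethenyl in place of chloromethyl moves the number further up. The overall change of a 30-fold higher number from compound 1 to compound 3 (1.47 log units; beyond the scatter) is the largest shown here, and it leaves compound 1, with its uncapped nitrogen, with the lowest number of the three, while both capped compounds read higher. Nothing measured here explains why the number rises with either change.

Going by these compounds, it remains open whether a cap carrying an amine or a carboxylic acid on this carbonyl carbon would bring the number back toward that of compound 1. On these data alone, it is also open whether a plain methyl, or a phenyl without the double bond, would read closer to compound 2 or to compound 3.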